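A few compounds are considered here, and "the series" means these few. Any claim that something is new, unique, unknown or untested is made for them only; others in the source may bear on it.

For the measured compounds named here, compound 2 `C[C@@H]1CC[C@@H](Oc2cc(Br)ccn2)CN1C(=O)c1ccccc1-n1nccn1` gives 130 nM in an assay on CHO-K1 cells for displacement of a labelled ligand from Orexin/Hypocretin receptor type 1 (Homo sapiens), read by radioligand binding (a lower number here means a stronger inhibitor, a higher number a weaker inhibitor), the higher of the two numbers measured so far; compound 1 `C#Cc1ccnc(O[C@@H]2CC[C@@H](C)N(C(=O)c3ccccc3-n3nccn3)C2)c1` gives 49 nM, and the step of a 2.7-fold higher number from compound 1 to compound 2 (0.42 log units; beyond the scatter) came with bromo in place of ethynyl. Compound 3 `Cc1cccnc1O[C@@H]1CC[C@@H](C)N(C(=O)c2ccccc2-n2nccn2)C1` differs from compound 2 by 3-methylpyridin-2-yl in place of 4-bromopyridin-2-yl on an oxygen on a saturated carbon. Going by the values given here, no measured step covers a methyl at this spot, and the single step from compound 1 to compound 2 was modest. The step of a 1.2-fold lower number from compound 2 to compound 3 (0.07 log units; within the scatter) is therefore expected to stay within the scatter. Compound 3 is estimated at 110 nM (range 35 nM to 400 nM).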

Compound 3, inhibition constant: 4760 nM
Compound 3: the middle estimate sits 43-fold (1.64 log units) below what was measured, and the stated range ends below it.
By their numbers in this assay, from the lowest: compound 1; then compound 2; then compound 3.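

In this assay the aryl group on the oxygen proves far from neutral: a 37-fold higher number from compound 2 to compound 3 (1.56 log units; beyond the scatter) and a 97-fold higher number from compound 1 to compound 3 (1.99 log units; beyond the scatter) are both large, whereas bromo in place of ethynyl gave only a 2.7-fold higher number from compound 1 to compound 2 (0.42 log units; beyond the scatter) in the earlier step. The 3-methylpyridin-2-yl group therefore gives a much weaker inhibitor than either 4-substituted pyridin-2-yl group. Nothing at hand explains this loss. Since the group and its place on the ring change together, their shares cannot be separated. From the compounds shown here alone, how a methoxy or an amine in place of the bromo of compound 2 would read also stays open.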